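Aryl swap on the oxazole-bearing series: compound 4

The source may report more compounds than this note shows. Statements on the series, on what has been measured and on what is new or still open speak of the compounds shown alone.

Among the compounds with values here, compound 1 `Cc1cc(C)c(-c2nc(CN3CCC(C(=O)NCCCN4C[C@H](C)C[C@H](C)C4)CC3)c(C)o2)c(C)c1` gives 6570 nM in an ADME assay on Huh7.5.1 cells (Homo sapiens) for cytotoxicity, read by ATP content, with a stated time of 48 h (a higher number here means that more compound is tolerated, a lower number that less compound is tolerated), the lowest of the three numbers so far. Compound 2 `Cc1oc(-c2ccc(Cl)cc2)nc1CN1CCC(C(=O)NCCCN2C[C@H](C)C[C@H](C)C2)CC1` gives 11500 nM, and compound 3 `Cc1ccccc1-c1nc(CN2CCC(C(=O)NCCCN3[C@H](C)CCC[C@@H]3C)CC2)c(C)o1` gives 21300 nM; compound 3 differs from compound 1 in two places, so its higher value is simply noted. Compound 4 `Cc1cc(C)cc(-c2nc(CN3CCC(C(=O)NCCCN4C[C@H](C)C[C@H](C)C4)CC3)c(C)o2)c1` carries 3,5-dimethylphenyl in place of 2,4,6-trimethylphenyl on an aromatic carbon. Within the data shown here, the one comparable step, a 1.8-fold higher number from compound 1 to compound 2 (0.24 log units; within the scatter), also exchanged the aryl group on an aromatic carbon of the shared core and stayed within the scatter. On that basis no step beyond the scatter is expected for a 1.2-fold higher number from compound 1 to compound 4 (0.09 log units; within the scatter), with a slight lean upward. Compound 4 is therefore estimated at 8000 nM, within the range 4000 nM to 16000 nM.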

Compound 4, half-maximal cytotoxic concentration: 4050 nM
Compound 4: the middle estimate sits 2.0-fold (0.30 log units) above what was measured; measured number inside the range.
By their numbers in this assay, from the lowest: compounds 4, 1, 2 and 3 (each within the scatter of the next, the first and the last beyond it).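

With a 1.6-fold lower number from compound 1 to compound 4 (0.21 log units; within the scatter) in this assay, the exchange of 2,4,6-trimethylphenyl for 3,5-dimethylphenyl stays small at this position on the aromatic carbon next to the ring nitrogen and next to the ring oxygen. The exchange of 4-chlorophenyl for 3,5-dimethylphenyl, with a 2.8-fold lower number from compound 2 to compound 4 (0.45 log units; beyond the scatter), is the only listed aryl step here to pass the scatter, and it remains modest. Nothing at hand accounts for either step.

Still open, as far as these compounds go, is whether a pyridyl group or a 4-carboxyphenyl group at this position would shift the number beyond the scatter from compound 1.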